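Adding a Methoxy Group to an Aromatic Ring

The source may report more compounds than this note shows. Statements on the series, on what has been measured and on what is new or still open speak of the compounds shown alone.

Compound 1 `COc1ccc(/C=C/C(=O)/C=C/C2=C(C)CCCC2(C)C)cc1OC` gives 29200 nM in a functional assay on IMR-32 cells (Homo sapiens) for cytotoxicity, read by sulforhodamine B assay, with a stated time of 48 h; a higher number here means a weaker inhibitor, a lower number a stronger inhibitor. Compound 2 `COc1cc(/C=C/C(=O)/C=C/C2=C(C)CCCC2(C)C)cc(OC)c1OC` carries the change (methoxy in place of hydrogen on an aromatic carbon), and in this assay compound 2 gives 55500 nM, a step of a 1.9-fold higher number from compound 1 to compound 2 (0.28 log units; within the scatter). Compound 3 `CC1=C(/C=C/C(=O)/C=C/C=C/c2ccccc2)C(C)(C)CCC1` is built on a different core, and the difference between the two cores is not broken down here; in this assay compound 3 gives 23400 nM. Compound 4 `COc1ccccc1/C=C/C=C/C(=O)/C=C/C1=C(C)CCCC1(C)C` arises from compound 3 by methoxy in place of hydrogen on an aromatic carbon. This is the same kind of change as that from compound 1 to compound 2, though the surroundings differ: in compound 2 the new group sits ortho to a methoxy group and meta to a large group, whereas in compound 4 it sits ortho to a large group. The step expected from compound 3 to compound 4 is a 1.4-fold higher number from compound 3 to compound 4 (0.14 log units; within the scatter), resting on the small step seen in a 1.9-fold higher number from compound 1 to compound 2 (0.28 log units; within the scatter). For compound 4 the estimated value in this assay is 32000 nM, between 13000 nM and 75000 nM.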

Compound 4, half-maximal inhibitory concentration: 72400 nM
Compound 4: middle estimate off by 2.3-fold (0.35 log units), on the low side, within the range that was stated.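

In this assay, methoxy in place of hydrogen on the aromatic ring gives a 3.1-fold higher number from compound 3 to compound 4 (0.49 log units; beyond the scatter), a weaker result on this second core. Set beside the earlier step, the change moves the number the same way on both cores, and the two sizes cannot be told apart: the same change on two cores in this assay, a 1.9-fold higher number (0.28 log units; within the scatter) from compound 1 to compound 2 and a 3.1-fold higher number (0.49 log units; beyond the scatter) from compound 3 to compound 4, 1.6-fold (0.21 log units) apart, within the scatter of two such steps. Among the compounds shown here, this suggests that the change carries over, but it rests on only two pairs, the earlier step alone lies within the scatter, and the methoxy group enters at different places on the two cores, so the effects of core and place cannot be separated.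

On these data alone, what remains open is how a methoxy group elsewhere on the phenyl ring of compound 3 would read. Also open, as far as these compounds go, is how an amine or a carboxylic acid would read in place of the methoxy group of compound 4.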